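Halogen swap on the para-substituted acylthiourea pair

The source may hold more compounds than are shown below. What is called first, only, known or untested is meant among the compounds shown, and "the series" means these compounds.

Two compounds carry numbers in an assay for inhibition of epoxide hydrolase 1 (Homo sapiens), read by fluorescence, using microsomes; a lower number here means a stronger inhibitor, a higher number a weaker inhibitor. Compound 1 `COc1cc([N+](=O)[O-])ccc1NC(=S)NC(=O)c1ccccc1` gives 1650 nM, and compound 2 `CC(=O)NC(=S)Nc1ccc(Br)cc1` gives 1640 nM; compound 2 holds the lower of the two numbers, though compound 1 sits within the scatter of it. Compound 3 `CC(=O)NC(=S)Nc1ccc(Cl)cc1` differs from compound 2 by chloro in place of bromo on an aromatic carbon. Going by the values given here, no measured pair shows this change, so no step beyond the scatter is expected in either direction, the estimated step being a 1.3-fold higher number from compound 2 to compound 3 (0.13 log units; within the scatter). Compound 3 is therefore estimated at 2200 nM, with a range from 900 nM to 5500 nM.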

Compound 3, half-maximal inhibitory concentration: 2210 nM
Compound 3: middle estimate off by 1.0-fold (0.00 log units), on the low side, within the range that was stated.
By their numbers in this assay, from the lowest: compounds 2, 1 and 3 (each within the scatter of the next).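

In this assay, going by these compounds alone, chloro in place of bromo on the aromatic carbon gives a 1.3-fold higher number from compound 2 to compound 3 (0.13 log units; within the scatter), the first measured single-place step. At this position, para to a group of 7 heavy atoms, the two halogens therefore cannot be told apart by this read-out. No supporting measurement bears on this step.

Still open, from the compounds shown here alone, is whether an amine or a carboxylic acid on this aromatic carbon would give a step beyond the scatter. Fluoro and iodo at this position also remain to be placed against the chloro and bromo pair.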